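Ring attachment point shift from compound 2 to compound 3

The source may hold more compounds than are shown below. What is called first, only, known or untested is meant among the compounds shown, and "the series" means these compounds.

Measured in an assay on HEK293 cells for inhibition of acid ceramidase (Homo sapiens), read by fluorescence, with stated times of 10 min and 3 h; a lower number here means a stronger inhibitor, a higher number a weaker inhibitor:
compound 1 `CC(C)CNC(=O)n1c(=O)oc2cc(C3CCCCN3C)ccc21`: 1010 nM
compound 2 `CC(C)CNC(=O)n1c(=O)oc2cc(C3CCCN(C)C3)ccc21`: 1750 nM

Compound 2 and compound 1 differ only in where the methylpiperidine ring is joined to the aromatic carbon, and the step of a 1.7-fold higher number from compound 1 to compound 2 (0.24 log units; within the scatter) lies within the scatter, so the two numbers are not separated. Compound 3 `CC(C)CNC(=O)n1c(=O)oc2cc(C3CCN(C)CC3)ccc21` continues this line: the change is 1-methylpiperidin-4-yl in place of 1-methylpiperidin-3-yl on an aromatic carbon. For the measured compounds named here, no measured step concerns this exact change; the only comparable one, the move of the attachment point from compound 1 to compound 2, gave a 1.7-fold higher number from compound 1 to compound 2 (0.24 log units; within the scatter), within the scatter. On that basis the step to compound 3 is expected to be small, with no direction beyond the scatter, and the estimated step is a 1.0-fold higher number from compound 2 to compound 3 (0.01 log units; within the scatter). Compound 3 is therefore expected to give about 1800 nM in this assay, within a range of 700 nM to 4500 nM.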

Compound 3, half-maximal inhibitory concentration: 166 nM
Compound 3: the middle estimate sits 11-fold (1.04 log units) above what was measured; measured number below the stated range.
By their numbers in this assay, from the lowest: compound 3; then compounds 1 and 2 (each within the scatter of the next).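

In this assay the attachment point of the methylpiperidine ring proves to matter: 1-methylpiperidin-4-yl in place of 1-methylpiperidin-3-yl gives an 11-fold lower number from compound 2 to compound 3 (1.02 log units; beyond the scatter) and in place of 1-methylpiperidin-2-yl gives a 6.1-fold lower number from compound 1 to compound 3 (0.78 log units; beyond the scatter) while the earlier pair stayed unseparated. The three compounds have the same atoms joined differently, so within this set only the 1-methylpiperidin-4-yl attachment stands apart from the other two. Nothing available explains why this attachment point differs from the others.

Still open, on these data alone, is whether the methyl group on the ring nitrogen matters at this attachment point, which an unsubstituted piperidin-4-yl or a 1-ethylpiperidin-4-yl group would address. Also open, as far as these compounds go, is whether the gain survives when the piperidine ring is replaced by an open-chain amine such as dimethylaminomethyl.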